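The compounds below may be only part of what the source reports. "The series", "measured", "known", "first", "only" and "open" are said of these compounds alone.

The study centres on an assay for inhibition of Indoleamine 2,3-dioxygenase 1 (Homo sapiens), with stated times of 10 min and 60 min; a lower number here means a stronger inhibitor, a higher number a weaker inhibitor. Three compounds carry a number there. Compound 1 `O=[N+]([O-])c1cc(Cl)ccc1CNc1cc(C(F)(F)F)cc2[nH]ncc12` gives 18000 nM in this assay. Compound 3 `O=[N+]([O-])c1ccccc1CNc1cc(Br)cc2[nH]ncc12` gives 8040 nM in this assay. Compound 2 `FC(F)(F)c1cccc(CNc2cc(C(F)(F)F)cc3[nH]ncc23)c1` is different: in this assay compound 2 gives > 100000 nM, which is a limit of the assay rather than a number, so only a limit is known for compound 2. That limit is the limit of > 100000 nM in this assay, at which 1 of the 3 values shown sits.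

Compound 4 `FC(F)(F)c1cc(NCc2cccc(Br)c2)c2cn[nH]c2c1` has not yet been measured. It differs from compound 2 in one place, by bromo in place of trifluoromethyl on an aromatic carbon of the benzyl ring. For the measured compounds named here, no pair of measured compounds shows this same change, so the size of the step cannot be read from the numbers at hand; compound 1 and compound 3 differ from compound 2 in other places and offer no direct comparison for this exchange.

The expectation is that the step from compound 2 to compound 4, a number no higher from compound 2 to compound 4 (the limit leaves the size open) in this assay, is none beyond the scatter, with a fair chance that the assay again reports only a limit for compound 4. Compound 4 is therefore estimated at 100000 nM in this assay, with a range from 30000 nM to 300000 nM.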

Compound 4, half-maximal inhibitory concentration: > 100000 nM
Compound 4: only a limit was reported (the forecaster's own chance of this, stated with the estimate: 60%); the middle value sits exactly at the limit.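

In this assay compound 4 gives > 100000 nM, which is a limit of the assay and not a number. For the compounds shown here, compound 2 also carries only a limit, so no step between compound 2 and compound 4 can be read. Compound 4 joins compound 2 at the same limit: the limit of > 100000 nM in this assay, at which 2 of the 4 values shown sit. The compounds shown leave open how far bromo in place of trifluoromethyl on an aromatic carbon shifts the inhibition.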